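The compounds below may be only part of what the source reports. "The series", "measured", "known", "first", "only" and "open" are said of these compounds alone.

Measured so far:
- Compound 1 `Nc1ncnc2c1ncn2CC(O)C(=O)OCCO`: in a functional assay on Vero cells (Chlorocebus sabaeus) for cytotoxicity (on this read-out higher numbers stand for lower toxicity in this test and lower numbers for higher toxicity in this test), compound 1 gives only a limit, > 400 ug/mL.
- Compound 2 `CCCCCCCCOC(=O)C(O)Cn1cnc2c(N)ncnc21`: in this assay compound 2 gives 200 ug/mL.
- Compound 3 `Nc1ncnc2c1ncn2CC(O)C(=O)OCc1ccco1`: in this assay compound 3 gives 40 ug/mL.

Of the two actual numbers, compound 2 stands highest, which in this assay means the lower toxicity. Its nearest neighbour is compound 3, reached by a 5.0-fold lower number from compound 2 to compound 3 (0.70 log units; beyond the scatter). Compound 1 contributes no number, only (the limit of > 400 ug/mL in this assay, at which 1 of the 3 values shown sits).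

Compound 4 `CC(C)COC(=O)C(O)Cn1cnc2c(N)ncnc21` has not been measured. It differs from compound 2 in one place: isopropyl in place of heptyl on a saturated chain carbon bound to an oxygen next to a carbonyl group. For the measured compounds named here, two measured steps touch this part of the molecule. First, an at least 2.0-fold lower number from compound 1 to compound 2 (0.30 log units; that floor lies within the scatter), a floor that lies within the scatter. Second, a 5.0-fold lower number from compound 2 to compound 3 (0.70 log units; beyond the scatter), a modest step. Replacing heptyl by a ring lowered the number; replacing hydroxy by hexyl did not clearly move it. None of the three compounds carries isopropyl, so the closest guide is compound 2 itself, with compound 1 showing that a shorter, ring-free ester end need not raise toxicity. In this assay the expected outcome is a 1.5-fold higher number from compound 2 to compound 4 (0.18 log units; within the scatter), a small movement. Compound 4 is therefore estimated at 300 ug/mL, with a range from 150 ug/mL to 600 ug/mL.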

Compound 4, minimum cytotoxic concentration: > 400 ug/mL
Compound 4 was reported as a limit; the forecaster's own chance of this, stated with the estimate: 30%; at least 1.3-fold (0.12 log units) between middle value and limit.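

In this assay compound 4 gives only a limit, > 400 ug/mL. At the place on a saturated chain carbon bound to an oxygen next to a carbonyl group, the change from heptyl to isopropyl gives an at least 2.0-fold higher number from compound 2 to compound 4 (0.30 log units; that floor lies within the scatter), so the shorter chain cannot yet be separated from the longer one, while the change from furan-2-yl to isopropyl gives an at least 10-fold higher number from compound 3 to compound 4 (1.00 log units; beyond the scatter), which shows that a small ring-free carbon chain at this place is clearly less toxic in this test than the furan-2-yl ester. Until now only the hydroxyl-bearing ester end of compound 1 had reached the top of the range, so compound 4 adds a plain carbon chain there, though the step between compound 1 and compound 4 cannot be read because both sit at that limit: the limit of > 400 ug/mL in this assay, at which 2 of the 4 values shown sit.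

The compounds shown leave open how long the chain can grow before the number clearly falls, which a butyl or pentyl chain would help to settle. They also leave open whether the lower number of compound 3 belongs to rings in general or to furan-2-yl alone, a question that a phenyl or cyclohexyl group at this place could address.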